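Trimming the Distal Triazole to a Terminal Alkyne

This account rests on a few compounds, and the source may have more. Where it says the series, first, only, none or still open, it means among the compounds named here.

Measured compounds:
Compound 1 `CNC(=O)[C@@]12C[C@@H]1[C@@H](n1cnc3c(NCc4cccc(Cl)c4)nc(C#CCCCCc4cn(-c5ccc(N)cc5)nn4)nc31)[C@H](O)[C@@H]2O` gives 87.1 nM in an assay on CHO cells for displacement of a labelled ligand from adenosine receptor A3 (Homo sapiens), read by scintillation counting; a lower number here means a stronger inhibitor, a higher number a weaker inhibitor.
Compound 2 `CNC(=O)[C@@]12C[C@@H]1[C@@H](n1cnc3c(NCc4cccc(Cl)c4)nc(C#CCCCCc4cn(Cc5ccc(-n6sccc6=O)cc5)nn4)nc31)[C@H](O)[C@@H]2O` gives 102 nM in this assay.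
Compound 3 `CNC(=O)[C@@]12C[C@@H]1[C@@H](n1cnc3c(NCc4cccc(Cl)c4)nc(C#CCCCCc4cn(-c5ccc(C(=O)O)cc5)nn4)nc31)[C@H](O)[C@@H]2O` gives 180 nM in this assay.

Compound 1 has the lowest of the three numbers. Going by the values given here, compound 2 lies within the scatter of it, while compound 3 sits further off: the change a 2.1-fold higher number from compound 1 to compound 3 (0.32 log units; beyond the scatter) is the only one-place step available, and it is modest. All three compounds share the core and the chain; they differ only in what hangs at the far end of the triazole.

Compound 4 `C#CCCCCC#Cc1nc(NCc2cccc(Cl)c2)c2ncn([C@H]3[C@H](O)[C@H](O)[C@]4(C(=O)NC)C[C@H]34)c2n1` is not yet measured. It differs from compound 1 by ethynyl in place of 1-(4-aminophenyl)-1H-1,2,3-triazol-4-yl on a saturated chain carbon, four bonds along the chain from a triple-bonded carbon. Among the compounds with values here, no measured step bears on this change directly, since the one known step alters only a substituent on the distal ring while here the whole ring system is gone. The three measured values span a narrow range, so the far end appears tolerant, and the step of a 1.5-fold lower number from compound 1 to compound 4 (0.16 log units; within the scatter) is expected to be small, with a slight lean toward a lower number. Compound 4 is therefore estimated at 60 nM, within 20 nM to 200 nM.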

Compound 4, inhibition constant: 29.4 nM
Compound 4: the middle estimate sits 2.0-fold (0.31 log units) above what was measured, and the stated range covers the measured number.
By their numbers in this assay, from the lowest: compound 4; then compounds 1, 2 and 3 (each within the scatter of the next, the first and the last beyond it).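

In this assay, replacing 1-(4-aminophenyl)-1H-1,2,3-triazol-4-yl with ethynyl on the saturated chain carbon gives a 3.0-fold lower number from compound 1 to compound 4 (0.47 log units; beyond the scatter). The earlier step changed only a substituent on the distal aromatic ring, whereas this one shows that the entire two-ring end group, with its 12 heavy atoms, 1 hydrogen-bond donor and 4 hydrogen-bond acceptors, can go and the number still falls. No measurement shown here accounts for this lower number.

As far as these compounds go, it remains open whether the step comes from losing the aminophenyl ring, losing the triazole, or gaining the terminal alkyne itself. A triazole without the aryl group, a terminal alkane or a terminal carboxylic acid on the same chain, or a shorter or longer chain ending in ethynyl, could separate these possibilities.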